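Aryl exchange on the enone carbonyl: compound 4 pending

The source may hold more compounds than are shown below. What is called first, only, known or untested is meant among the compounds shown, and "the series" means these compounds.

Measured compounds:
- compound 1 `Cn1cc(/C=C/C(=O)c2ccccc2F)cc1/C=C/C(=O)NO`, which in an assay on isolated protein for inhibition of histone deacetylase HD1B (Zea mays) (a higher number here means a weaker inhibitor, a lower number a stronger inhibitor), gives 3400 nM
- compound 2 `Cn1cc(/C=C/C(=O)c2cccc(Br)c2)cc1/C=C/C(=O)NO`, which in this assay gives 480 nM
- compound 3 `Cc1cccc(C(=O)/C=C/c2cc(/C=C/C(=O)NO)n(C)c2)c1`, which in this assay gives 2500 nM

Compound 3 stands second highest of the three numbers. Its nearest neighbour is compound 1, and the step of a 1.4-fold lower number from compound 1 to compound 3 (0.13 log units; within the scatter) lies within the scatter, so no order between these two can be read. Its furthest neighbour is compound 2, with the step of a 5.2-fold higher number from compound 2 to compound 3 (0.72 log units; beyond the scatter) lying beyond the scatter.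

The next compound, compound 4 `Cn1cc(/C=C/C(=O)c2ccco2)cc1/C=C/C(=O)NO`, differs from compound 3 in one place: furan-2-yl in place of 3-methylphenyl on a carbonyl carbon.

All three measured steps exchange the group on this same carbonyl carbon: a 7.1-fold lower number from compound 1 to compound 2 (0.85 log units; beyond the scatter), a 1.4-fold lower number from compound 1 to compound 3 (0.13 log units; within the scatter) and a 5.2-fold higher number from compound 2 to compound 3 (0.72 log units; beyond the scatter). Among the measured compounds shown here, the spread across the three aryl groups is modest at most, and none of the measured steps involves furan-2-yl, so no direct precedent exists. The expectation is therefore no step beyond the scatter in this assay, with no change at the digits printed from compound 3 to compound 4 (within the scatter) as the estimated step from compound 3 to compound 4, and the range kept wide to cover a shift of the size seen among the measured aryl groups.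

For compound 4 the estimated value in this assay is 2500 nM, with a range from 700 nM to 9000 nM.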

Compound 4, half-maximal inhibitory concentration: 19700 nM
Estimate against measurement, compound 4: 7.9-fold (0.90 log units) below, and the stated range ends below it.
By their numbers in this assay, from the lowest: compound 2; then compounds 3 and 1 (each within the scatter of the next); then compound 4.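

In this assay this carbonyl position proves more sensitive than the three substituted phenyl groups could show: furan-2-yl gives a higher number than each of them (a 7.9-fold higher number from compound 3 to compound 4 (0.90 log units; beyond the scatter); a 5.8-fold higher number from compound 1 to compound 4 (0.76 log units; beyond the scatter); a 41-fold higher number from compound 2 to compound 4 (1.61 log units; beyond the scatter)), and all three steps lie beyond the scatter. Compounds 1 and 3 lie within the scatter of each other, so until now only the 3-bromophenyl of compound 2 stood apart, at the low end, whereas compound 4 now marks a clear high end and is the weakest inhibitor of the four. Nothing shown here explains the rise at this exchange.

The exchange changes several things at once: the ring goes from six-membered to five-membered, an oxygen enters the ring, and the ring substituent is lost, so the compounds shown cannot say which of these goes with the higher number. An unsubstituted phenyl, a thiophen-2-yl and a 5-bromofuran-2-yl on this carbonyl carbon would each separate these changes, and would show whether bromo lowers the number on a five-membered ring as well.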